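Swapping methoxy for hydroxy on a pyrazole urea

This account rests on a few compounds, and the source may have more. Where it says the series, first, only, none or still open, it means among the compounds named here.

Compound 1 `O=C(Nc1cccc(-n2cc(-c3ccncc3)c(-c3ccc(Cl)c(O)c3)n2)c1)Nc1cccc(C(F)(F)F)c1` gives 9820 nM in a functional assay on HT-29 cells (Homo sapiens) for inhibition, read by sulforhodamine B assay, with a stated time of 48 h; a lower number here means a stronger inhibitor of growth, a higher number a weaker inhibitor of growth.
Compound 2 `O=C(Nc1cccc(-n2cc(-c3ccncc3)c(-c3ccc(Cl)c(O)c3)n2)c1)Nc1ccc(Cl)c(Cl)c1` gives 4890 nM in this assay.
Compound 3 `COc1cc(-c2nn(-c3cccc(NC(=O)Nc4ccc(Cl)c(C(F)(F)F)c4)c3)cc2-c2ccncc2)ccc1Cl` gives 1190 nM in this assay.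

Compound 3 has the lowest number of the three, and its distance to compound 2 and to compound 1 lies beyond the usual scatter, so it is the strongest growth inhibitor here. Compound 4 `O=C(Nc1cccc(-n2cc(-c3ccncc3)c(-c3ccc(Cl)c(O)c3)n2)c1)Nc1ccc(Cl)c(C(F)(F)F)c1` is its close relative: the change is hydrogen in place of methyl on an oxygen on an aromatic ring, so the methoxy of compound 3 becomes a hydroxy, as in compounds 1 and 2.

Among the compounds with values here, none of the measured steps touches this oxygen. Within the data shown here, the only measured step, a 2.0-fold lower number from compound 1 to compound 2 (0.30 log units; within the scatter), concerns the aryl group on the urea nitrogen and lies within the scatter, so changing that aryl did little between two hydroxy compounds. Compound 4 differs from compound 2 and from compound 1 only in that same aryl group, which makes the hydroxy compounds 1 and 2 the nearest guide to it, while compound 3, with 1190 nM, differs from both of them in its methoxy and in its aryl at once. A weaker inhibitor than compound 3 is therefore expected, with wide uncertainty, and the step of a 3.4-fold higher number from compound 3 to compound 4 (0.53 log units; beyond the scatter) is the estimated size. Compound 4 is expected at 4000 nM, between 1200 nM and 12000 nM.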

Compound 4, concentration for 50% growth inhibition: 1280 nM
Compound 4: the middle estimate sits 3.1-fold (0.49 log units) above what was measured; low and high end bracket the measured number.
By their numbers in this assay, from the lowest: compounds 3 and 4 (each within the scatter of the next); then compounds 2 and 1 (each within the scatter of the next).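

In this assay, the step of a 1.1-fold higher number from compound 3 to compound 4 (0.03 log units; within the scatter) lies within the scatter, so with this aryl group on the urea, methoxy and hydroxy on the aromatic ring cannot be told apart. The aryl group on the urea does matter among the hydroxy compounds, which the earlier step of a 2.0-fold lower number from compound 1 to compound 2 (0.30 log units; within the scatter), within the scatter, did not show: the result includes a 3.8-fold lower number from compound 2 to compound 4 (0.58 log units; beyond the scatter) and a 7.7-fold lower number from compound 1 to compound 4 (0.88 log units; beyond the scatter), both beyond the scatter. No measurement shown here bears on the reason for these steps.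

Within the data shown here, the methoxy to hydroxy change is seen with only one aryl group on the urea, so it remains open whether it would make as little difference with the aryl groups of compound 1 and compound 2. Also open, on these data alone, is how the number in this assay would respond to a longer chain on this oxygen, such as ethoxy, or to an amine in place of the hydroxy.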